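A few compounds are considered here, and "the series" means these few. Any claim that something is new, unique, unknown or untested is made for them only; others in the source may bear on it.

Measured in an assay on HEK293 cells for displacement of a labelled ligand from Melanocortin receptor 4 (Homo sapiens); a higher number here means a weaker inhibitor, a lower number a stronger inhibitor:
compound 1 `CCC(C)[C@H](NCC1CCCO1)c1cc(C(F)(F)F)ccc1N1CCN(C(=O)CCc2ccc(Cl)cc2Cl)CC1` gives 780 nM
compound 2 `CCC(C)[C@H](NC[C@H]1CCCN1)c1cc(C(F)(F)F)ccc1N1CCN(C(=O)CCc2ccc(Cl)cc2Cl)CC1` gives 110 nM
compound 3 `CCC(C)[C@H](NC[C@@H]1CCCN1)c1cc(C(F)(F)F)ccc1N1CCN(C(=O)CCc2ccc(Cl)cc2Cl)CC1` gives 64 nM

Compound 3 and compound 2 lie within the scatter of each other a 1.7-fold lower number from compound 2 to compound 3 (0.24 log units; within the scatter); both stand well apart from compound 1, with a 12-fold lower number from compound 1 to compound 3 (1.09 log units; beyond the scatter) and a 7.1-fold lower number from compound 1 to compound 2 (0.85 log units; beyond the scatter). Each of those two steps puts pyrrolidin-2-yl in place of oxolan-2-yl on the saturated chain carbon bound to the amine nitrogen.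

Compound 4 `CCC(C)[C@H](NC(=O)CN)c1cc(C(F)(F)F)ccc1N1CCN(C(=O)CCc2ccc(Cl)cc2Cl)CC1` carries a different change: (aminomethyl)carbonyl in place of (pyrrolidin-2-yl)methyl on an amine nitrogen. Among the measured compounds shown here, no measured step makes this exchange. The steps from compound 1 show the number falling when the ring nitrogen enters; compound 4 keeps a nitrogen in the entering group but loses the ring and places a carbonyl on the amine nitrogen. The expected step is a 3.9-fold higher number from compound 3 to compound 4 (0.59 log units; beyond the scatter), a rise in this assay. Compound 4 is estimated at 250 nM, with a range from 60 nM to 1000 nM.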

Compound 4, inhibition constant: 18 nM
Compound 4: the middle estimate sits 14-fold (1.14 log units) above what was measured; the measured number lies below the stated range.
By their numbers in this assay, from the lowest: compound 4; then compounds 3 and 2 (each within the scatter of the next); then compound 1.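

On the amine nitrogen, the pyrrolidine ring is not required for a low number in this assay: (aminomethyl)carbonyl gives a 3.6-fold lower number from compound 3 to compound 4 (0.55 log units; beyond the scatter) and a 6.1-fold lower number from compound 2 to compound 4 (0.79 log units; beyond the scatter). Against the oxolane compound the same group gives a 43-fold lower number from compound 1 to compound 4 (1.64 log units; beyond the scatter), so this open-chain group with a carbonyl on the nitrogen stands apart from all three earlier compounds. Nothing at hand accounts for this gain.

On these data alone, whether the carbonyl or the loss of the ring carries the step stays open, as both changes arrive together. A 2-aminoethyl chain or a pyrrolidin-2-ylcarbonyl group on the same nitrogen would separate them.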